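A few compounds are considered here, and "the series" means these few. Any claim that something is new, unique, unknown or untested is made for them only; others in the source may bear on it.

Measured compounds in a functional assay on SF-539 cells (Homo sapiens) for inhibition, read by sulforhodamine B assay, with a stated time of 48 h; a higher number here means a weaker inhibitor of growth, a lower number a stronger inhibitor of growth:
compound 1 `COc1cc(-c2nn(-c3cccc(NC(=O)Nc4cc(C(F)(F)F)cc(C(F)(F)F)c4)c3)cc2-c2ccncc2)ccc1Cl` gives 829 nM
compound 2 `COc1cc(-c2nn(-c3cccc(NC(=O)c4cccc(C(F)(F)F)c4)c3)cc2-c2ccncc2)ccc1Cl` gives 895 nM
compound 3 `COc1cc(-c2nn(-c3cccc(NC(=O)Nc4ccc(Cl)c(Cl)c4)c3)cc2-c2ccncc2)ccc1Cl` gives 965 nM

Compound 3 has the largest of the three numbers, but the gaps to compound 2 and to compound 1 are both within the scatter, so the three measured compounds are not separable in this assay. Among the measured compounds shown here, the one single-point step measured so far, a 1.1-fold higher number from compound 2 to compound 3 (0.03 log units; within the scatter), changes both the linker and the aryl group and still stays within the scatter.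

Compound 4 `COc1cc(-c2nn(-c3cccc(NC(=O)Nc4cccc(C(F)(F)F)c4)c3)cc2-c2ccncc2)ccc1Cl` differs from compound 3 by 3-(trifluoromethyl)phenyl in place of 3,4-dichlorophenyl on an amide-type nitrogen. Compound 4 thus carries the urea of compound 3 and the 3-(trifluoromethyl)phenyl of compound 2. For the measured compounds named here, compound 2 and compound 3 sit within the scatter of each other, and compound 1, another urea, sits alongside them, so no measured step points to a change in either direction. The expected step is a 1.1-fold lower number from compound 3 to compound 4 (0.04 log units; within the scatter), no change beyond the scatter. The estimated value for compound 4 in this assay is 880 nM, with an expected range of 450 nM to 1800 nM.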

Compound 4, concentration for 50% growth inhibition: 890 nM
Beside the measured number, compound 4's estimate is 1.0-fold (0.00 log units) below it, and the stated range covers the measured number.
By their numbers in this assay, from the lowest: compounds 1, 4, 2 and 3 (each within the scatter of the next).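

In this assay, the aryl group on the amide-type nitrogen of the urea can now be read on its own: 3-(trifluoromethyl)phenyl in place of 3,4-dichlorophenyl gives a 1.1-fold lower number from compound 3 to compound 4 (0.04 log units; within the scatter), so this exchange does not separate the two ureas. With the 3-(trifluoromethyl)phenyl group held fixed, the amide-to-urea change gives a 1.0-fold lower number from compound 2 to compound 4 (0.00 log units; within the scatter), and hydrogen in place of trifluoromethyl on an aromatic carbon gives a 1.1-fold higher number from compound 1 to compound 4 (0.03 log units; within the scatter), so neither the linker nor the second trifluoromethyl moves the number beyond the scatter. No supporting data bear on why these changes leave the number flat.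

From the compounds shown here alone, it remains open whether a morpholine or a carboxylic acid on this aryl ring would move the number beyond the scatter. The same question stands for a butyl chain in place of the aryl group on the amide-type nitrogen.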